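The compounds below may be only part of what the source reports. "The series", "measured", "known", "first", "only" and "open" are said of these compounds alone.

Measured in a functional assay on cells (Cancer cell lines, Homo sapiens) for cytotoxicity, read by sulforhodamine B assay, with a stated time of 48 h; a higher number here means a weaker inhibitor of growth, a lower number a stronger inhibitor of growth:
compound 1 `O=C1N=C(N2N=C(c3ccccc3)CC2c2ccccc2O)S/C1=C1/C(=O)Nc2ccc(Br)cc21` gives 230 nM;
compound 2 `COc1ccc(C2CC(c3ccccc3)=NN2C2=NC(=O)/C(=C3\C(=O)Nc4ccc(Br)cc43)S2)cc1` gives 180 nM;
compound 3 `CN(C)c1ccc(C2CC(c3ccccc3)=NN2C2=NC(=O)/C(=C3\C(=O)Nc4ccccc43)S2)cc1` gives 6370 nM.

Compound 3 stands at the highest number of the three, well beyond the scatter from compound 1 and from compound 2. Compound 4 `CN(C)c1ccc(C2CC(c3ccccc3)=NN2C2=NC(=O)/C(=C3\C(=O)Nc4ccc(Br)cc43)S2)cc1` differs from compound 3 by one change: bromo in place of hydrogen on an aromatic carbon, on a six-membered aromatic ring of carbon only within a fused system. Among the compounds with values here, the only measured step, a 1.3-fold lower number from compound 1 to compound 2 (0.11 log units; within the scatter), concerns a different part of the molecule and is within the scatter, so it does not speak to this change. Going by these compounds, the values of compound 1 and compound 2, which both carry bromo, lie far below that of compound 3, but they differ from compound 3 in two places, so the share of the bromo alone is unknown. Compound 4 is therefore expected to give a lower number, a 5.3-fold lower number from compound 3 to compound 4 (0.72 log units; beyond the scatter), with the estimate 1200 nM and range 300 nM to 5000 nM.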

Compound 4, concentration for 50% growth inhibition: 200 nM
Compound 4: middle estimate off by 6.0-fold (0.78 log units), on the high side; measured number below the stated range.
By their numbers in this assay, from the lowest: compounds 2, 4 and 1 (each within the scatter of the next); then compound 3.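

In this assay, within the data shown here, bromo in place of hydrogen on this aromatic carbon, taken alone, gives a 32-fold lower number from compound 3 to compound 4 (1.50 log units; beyond the scatter), the first reading of this change in isolation. With bromo present, the aryl group on the saturated ring carbon makes no difference beyond the scatter: dimethylamino in place of methoxy gives a 1.1-fold higher number from compound 2 to compound 4 (0.05 log units; within the scatter), and 4-(dimethylamino)phenyl in place of 2-hydroxyphenyl gives a 1.2-fold lower number from compound 1 to compound 4 (0.06 log units; within the scatter). Nothing available explains the size of the bromo step. Going by these compounds, it remains open whether chloro, fluoro or methyl on this carbon would match bromo. Also open, on these data alone, is whether 2-hydroxyphenyl and 4-methoxyphenyl would match 4-(dimethylamino)phenyl on a core with hydrogen there.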